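Benzyl for methyl on selenium in a bis-amide series

The source may report more compounds than this note shows. Statements on the series, on what has been measured and on what is new or still open speak of the compounds shown alone.

Measured compounds:
compound 1, `C[Se]/C(=N\C(=O)c1ccco1)NC(=O)c1ccco1`, 88900 nM
compound 2, `CS/C(=N\C(=O)c1sccc1Cl)NC(=O)c1sccc1Cl`, 57100 nM
compound 3, `C[Se]/C(=N\C(=O)c1cnc2ccccc2c1)NC(=O)c1cnc2ccccc2c1`, 8030 nM

Of the compounds shown here, three have been tested in a functional assay on MCF7 cells (Homo sapiens) for cytotoxicity, read by MTT assay, with a stated time of 72 h; on this read-out higher numbers stand for weaker inhibition of growth and lower numbers for stronger inhibition of growth. Compound 1 gives 88900 nM and compound 2 gives 57100 nM in this assay. Compound 3, which carries a quinoline-derived amide on both sides of the central carbon, gives 8030 nM and so stands with the lowest number of the three; its gaps to compound 2 and to compound 1 are both beyond the usual scatter, so it is the strongest inhibitor of growth among the measured compounds.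

Compound 4, `O=C(/N=C(/NC(=O)c1cnc2ccccc2c1)[Se]Cc1ccccc1)c1cnc2ccccc2c1`, keeps the core of compound 3 and differs from it in one place: phenyl in place of hydrogen on a saturated chain carbon bound to a selenium atom. Among the measured compounds shown here, no pair of measured compounds shows this kind of change, so nothing here tells how the assay responds to it. The account therefore rests on compound 3 alone. The step is expected to be small and, as estimated, in the direction of a slightly lower number, a 1.3-fold lower number from compound 3 to compound 4 (0.13 log units; within the scatter), though a change within the scatter would be no surprise. Compound 4 is expected to give about 6000 nM in this assay, with a range from 1500 nM to 25000 nM.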

Compound 4, concentration for total growth inhibition: > 100000 nM
Compound 4: a limit, no number; the forecaster's own chance of this, stated with the estimate: 5%; middle value at least 16-fold (1.22 log units) from the limit.
By their numbers in this assay, from the lowest: compound 3; then compounds 2 and 1 (each within the scatter of the next). At a limit, above all of these: compound 4.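

Among the compounds shown here, the step from methyl to benzyl is the first change in one place that this series offers, and it is a large one in this assay: an at least 12-fold higher number from compound 3 to compound 4 (1.09 log units; beyond the scatter). For the compounds shown here, it shows that the saturated chain carbon bound to a selenium atom is not a neutral place for a phenyl group on the core of compound 3, something the earlier compounds could not show, since no two of them differed in one place only. Because compound 4 is held at a limit of the assay rather than a number, the step gives only the smallest size the change can have, and its true size stays unknown: the limit of > 100000 nM in this assay, at which 1 of the 4 values shown sits.

Going by these compounds alone, the single pair leaves open whether the loss belongs to the phenyl ring itself or would also follow from a smaller or different group there, such as an ethyl group, a longer chain or a benzyl group carrying an amine or a carboxylic acid. It also leaves open whether the same change from methyl to benzyl would read alike on the core of compound 1.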